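The source may report more compounds than this note shows. Statements on the series, on what has been measured and on what is new or still open speak of the compounds shown alone.

Measured compounds:
- compound 1, `C=C1CC[C@H]2C(C)(C)CCC[C@]2(C)[C@H]1CC(O)c1ccoc1`: 47.2 ug/mL
- compound 2, `C=C1[C@H](O)C[C@H]2C(C)(C)CCC[C@]2(C)[C@H]1/C=C/c1ccoc1`: 27.3 ug/mL
- compound 3, `CC(=O)O[C@]1(C)CC[C@H]2C(C)(C)CCC[C@]2(C)[C@H]1CC=O`: 31.9 ug/mL

In a functional assay on B16 cells (Mus musculus) for cytotoxicity (on this read-out higher numbers stand for weaker inhibition and lower numbers for stronger inhibition), the three compounds fall close together. Compound 1 has the largest number of the three, but compound 3 and compound 2 both lie within the usual scatter of it, so the three numbers cannot be placed in any firm order on this evidence.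

Compound 4, `C=C1CC[C@H]2C(C)(C)CCC[C@]2(C)[C@H]1C/C=C(\CO)CCO`, is the next compound to be measured in this assay and has not yet been measured. It differs from compound 1 in one place: 4-hydroxy-2-(hydroxymethyl)but-1-en-1-yl in place of (furan-3-yl)(hydroxy)methyl on a saturated chain carbon bound to a saturated ring carbon. The shared core is unchanged; only the side group on that chain carbon is exchanged.

For the measured compounds named here, no step between measured compounds of this kind exists, so the expected size of the step rests only on the narrow spread among compound 1, compound 2 and compound 3. The step of a 1.2-fold higher number from compound 1 to compound 4 (0.07 log units; within the scatter) is therefore expected to be small, with no clear direction beyond the scatter, leaning if anything toward a slightly higher number. Compound 4 is estimated to give 55 ug/mL in this assay, with a range from 25 ug/mL to 120 ug/mL.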

Compound 4, half-maximal inhibitory concentration: 28.9 ug/mL
Estimate against measurement, compound 4: 1.9-fold (0.28 log units) above; low and high end bracket the measured number.
By their numbers in this assay, from the lowest: compounds 2, 4, 3 and 1 (each within the scatter of the next).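

In this assay, for the compounds shown here, putting 4-hydroxy-2-(hydroxymethyl)but-1-en-1-yl in place of (furan-3-yl)(hydroxy)methyl on a saturated chain carbon bound to a saturated ring carbon gives a 1.6-fold lower number from compound 1 to compound 4 (0.21 log units; within the scatter) as the first step that can be read at this position. The earlier compounds shown here offered no such single-place comparison, whereas this pair shows that the five-membered aromatic ring can give way to an open chain with no ring, while the shared core stays the same, without the number moving beyond the scatter. Nothing at hand bears on why this exchange leaves the number within the scatter.

From the compounds shown here alone, whether an amine, a carboxylic acid or a longer chain on this same chain carbon would carry the number beyond the scatter remains open. Also open, going by these compounds, is whether either hydroxy group of 4-hydroxy-2-(hydroxymethyl)but-1-en-1-yl, or its double bond, matters on its own, and a single step within the scatter gives no direction for any of these groups.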